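Two Methyl Groups on the Hydrazone Phenyl

The source may hold more compounds than are shown below. What is called first, only, known or untested is meant among the compounds shown, and "the series" means these compounds.

Compound 1, `O=[N+]([O-])c1ccccc1NN=C(c1ccc(O)cc1)c1ccc(O)cc1`, in a functional assay on cells (Melanoma tumor cell line, Homo sapiens) for cytotoxicity (on this read-out lower numbers stand for stronger inhibition and higher numbers for weaker inhibition), gives 3.9 ug/mL.
Compound 2, `Oc1ccc(C(=NNc2ccccc2)c2ccc(O)cc2)cc1`, in this assay gives > 5 ug/mL, which is a limit of the assay and not a number.

Both compounds share a core carrying two hydroxyphenyl groups on a carbon joined by a double bond to a hydrazone nitrogen; they differ only in the aryl group on the amine nitrogen. On the numbers shown, compound 2 stands at the edge of what the assay reports: the limit of > 5 ug/mL in this assay, at which 1 of the 2 values shown sits. Within the data shown here, the single measured step, an at least 1.2-fold higher number from compound 1 to compound 2 (0.10 log units; that floor lies within the scatter), concerns the removal of a nitro group, and its true size is not known since compound 2 is a limit. Compound 3, `Cc1ccc(NN=C(c2ccc(O)cc2)c2ccc(O)cc2)c(C)c1`, arises from compound 2 by 2,4-dimethylphenyl in place of phenyl on an amine nitrogen. Among the measured compounds shown here, no measured step involves a methyl group, and the nitro step offers no direct guide. Compound 3 is therefore expected to stay near compound 2. The step that the limit leaves unreadable from compound 2 to compound 3 is expected to be small. For compound 3 the estimate is 6 ug/mL, within 3 ug/mL to 12 ug/mL.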

Compound 3, half-maximal inhibitory concentration: 10 ug/mL
The estimate for compound 3 lay 1.7-fold (0.22 log units) below the measured number; the range from low to high includes it.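

Among these compounds, compound 3 gives a real number, but no step from compound 2 to compound 3 can be read in this assay, because compound 2 is reported only as a limit and not as a number: the limit of > 5 ug/mL in this assay, at which 1 of the 3 values shown sits.
The compounds shown leave open how large the change from phenyl to 2,4-dimethylphenyl really is, and in which direction it goes.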